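Pyrrolidine to 3-cyanopiperidine: expected kinetic solubility

A few compounds are considered here, and "the series" means these few. Any claim that something is new, unique, unknown or untested is made for them only; others in the source may bear on it.

Measured compounds:
compound 1 `COc1cc(Nc2nc(C)cc(N3CCCCC3)n2)ccc1F`, which in a physicochemical assay for solubility, read by nephelometry, measured as kinetic solubility (a lower number here means a less soluble compound, a higher number a more soluble compound), gives 160000 nM
compound 2 `COc1cc(Nc2nc(C)cc(N3CCCC3)n2)ccc1F`, which in this assay gives 220000 nM

Compound 2 is the closer relative of the new compound; the step of a 1.4-fold higher number from compound 1 to compound 2 (0.14 log units; within the scatter) is within the scatter, so compound 1 and compound 2 stand together. Compound 3 `COc1cc(Nc2nc(C)cc(N3CCCC(C#N)C3)n2)ccc1F` carries 3-cyanopiperidin-1-yl in place of pyrrolidin-1-yl on an aromatic carbon. Among the compounds with values here, the one measured step exchanged the same two ring sizes without moving beyond the scatter, and no measured step covers the added nitrile. The expected step is therefore a 1.3-fold lower number from compound 2 to compound 3 (0.11 log units; within the scatter). Compound 3 is estimated at 170000 nM, with a range from 80000 nM to 350000 nM.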

Compound 3, solubility: 219000 nM
Beside the measured number, compound 3's estimate is 1.3-fold (0.11 log units) below it, within the range that was stated.
By their numbers in this assay, from the lowest: compounds 1, 3 and 2 (each within the scatter of the next).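

In this assay, cyano in place of hydrogen on a saturated ring carbon gives a 1.4-fold higher number from compound 1 to compound 3 (0.14 log units; within the scatter), and 3-cyanopiperidin-1-yl in place of pyrrolidin-1-yl gives a 1.0-fold lower number from compound 2 to compound 3 (0.00 log units; within the scatter). At this position, therefore, the three groups stand together, and the set now includes a ring bearing a nitrile, which the earlier pair could not show. Nothing available explains this result. On these data alone, whether a carboxylic acid or a primary amine on the same saturated ring would give a step beyond the scatter remains open.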